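A few compounds are considered here, and "the series" means these few. Any claim that something is new, unique, unknown or untested is made for them only; others in the source may bear on it.

In an in vitro ADME assay on microsomes from liver (Homo sapiens) for metabolic stability (a lower number here means slower removal, a higher number faster removal of the compound), compound 1 `Cc1cnc(NC(=O)c2cc(Oc3cnc(C(=O)N(C)C)cn3)c3cc(C)nn3c2)cn1` gives 13.7 mL/min/kg. For the measured compounds named here, compound 2 `Cc1cnc(NC(=O)c2cc(Oc3ccc(C(=O)N(C)C)cc3)c3cn(C)nc3c2)cn1` gives 12.3 mL/min/kg, and these two numbers lie within the usual scatter of each other, so compound 2 stands level with the only other measured compound. Compound 3 `Cc1cnc(NC(=O)c2cc(Oc3ccc(S(C)(=O)=O)cc3)c3cn(C)nc3c2)cn1` keeps the rest of compound 2 and changes one group: it has methylsulfonyl in place of dimethylcarbamoyl on an aromatic carbon, para to a large group (methylsulfonyl in place of dimethylcarbamoyl on an aromatic carbon). Going by the values given here, no measured pair of compounds shows this exchange, so the data offer no direct guide to its size or direction. With nothing to point either way, no change beyond the scatter is expected in this assay. The estimated step of a 1.1-fold lower number from compound 2 to compound 3 (0.05 log units; within the scatter) is therefore small. In this assay the estimated clearance of compound 3 is 11 mL/min/kg, with an expected range from 6 mL/min/kg to 20 mL/min/kg.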

Compound 3, clearance: < 8 mL/min/kg
Compound 3 was reported as a limit (the forecaster's own chance of this, stated with the estimate: 5%); middle value at least 1.3-fold (0.13 log units) from the limit.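

Compound 2 and compound 1 differ in more than one place, so neither could show what a single exchange does on this six-membered aromatic ring of carbon only, para to a large group. In this assay, methylsulfonyl in place of dimethylcarbamoyl gives an at least 1.5-fold lower number from compound 2 to compound 3 (0.18 log units; that floor lies within the scatter), so this exchange brings no faster removal. Compound 3 is reported only as a limit, < 8 mL/min/kg.

The full size of the step stays unknown because the result is a limit: the limit of < 8 mL/min/kg in this assay, at which 1 of the 3 values shown sits.

On these data alone, whether other groups at this position, such as a nitrile or a carboxylic acid, would give a similar result remains open. Also open, as far as these compounds go, is whether the same exchange would behave alike on the core of compound 1.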